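Replacing the tetrazolyl group with a bicyclic carbon group

A few compounds are considered here, and "the series" means these few. Any claim that something is new, unique, unknown or untested is made for them only; others in the source may bear on it.

Compound 3 `CCCn1c(=O)c2nc(-c3nn[nH]n3)[nH]c2n(CCC)c1=O` is a xanthine-type compound that carries a 2H-tetrazol-5-yl group on the shared core. Going by the values given here, in an assay on cell membranes for binding affinity to adenosine receptor A1 (Cavia porcellus), read by radioligand binding (a lower number here means a stronger inhibitor, a higher number a weaker inhibitor), compound 3 reaches only the limit of the assay, > 10000 nM, so no number is known for it; this is the only compound of the three measured that sits at the limit of > 10000 nM in this assay, at which 1 of the 3 values shown sits. The closest measured partner is compound 1 `CCCn1c(=O)c2nc(C(C)(C)CCC)[nH]c2n(CCC)c1=O`, which bears a 1,1-dimethylbutyl group at the same place and in this assay gives 25 nM. The step of an at least 400-fold higher number from compound 1 to compound 3 (2.60 log units; beyond the scatter) shows that exchanging that carbon-only group for the tetrazolyl group costs almost all of the affinity. Compound 2 `CC(C)(C)CNc1ncnc2c1ncn2C1O[C@H](CO)[C@@H](O)[C@H]1O`, of a different core, gives 17 nM in this assay.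

Compound 4 `CCCn1c(=O)c2nc([C@@H]3CC4CCC3C4)[nH]c2n(CCC)c1=O` differs from compound 3 in one place: a group of 7 heavy atoms (7 carbon; 2 five-membered non-aromatic rings of carbon only) in place of a group of 5 heavy atoms (1 carbon, 4 nitrogen; one five-membered aromatic ring with 4 hetero atoms), on an aromatic carbon. This change moves back towards the pattern of compound 1, where a carbon-only group at this position gave 25 nM. The step from compound 3 to compound 4 is therefore expected to run in the opposite direction to the measured step and to be large, namely an at least 400-fold lower number from compound 3 to compound 4 (2.60 log units; beyond the scatter). Compound 4 is estimated to give 25 nM in this assay, within a range of 5 nM to 150 nM.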

Compound 4, inhibition constant: 3.8 nM
Compound 4: middle estimate off by 6.6-fold (0.82 log units), on the high side; the measured number lies below the stated range.
By their numbers in this assay, from the lowest: compound 4; then compounds 2 and 1 (each within the scatter of the next). At a limit, above all of these: compound 3.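

Compound 3 stands only at a limit of the assay, so an at least 2600-fold lower number from compound 3 to compound 4 (3.42 log units; beyond the scatter) in this assay gives a bound on the size of the change and not an exact size: the limit of > 10000 nM in this assay, at which 1 of the 4 values shown sits.

The carbon-only group of compound 1 was not the best that this place can carry, as the bicyclic group gives a 6.6-fold lower number from compound 1 to compound 4 (0.82 log units; beyond the scatter), a modest step but one beyond the scatter. A ring on this aromatic carbon is therefore not in itself what goes with the loss of affinity in compound 3, as compound 4 also carries rings there, of carbon only, and keeps a low number.

The compounds shown leave open whether the loss follows from the four ring nitrogen atoms of the 2H-tetrazol-5-yl group or from its aromatic ring, a question that a phenyl ring at the same place would help to settle. They also leave open whether the defined stereocentre of compound 4 matters, and how much of the bicyclic group is needed, which a single cyclopentyl ring would begin to show.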